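The compounds below may be only part of what the source reports. "The series", "measured", "known", "first", "only" and "open" are said of these compounds alone.

- Compound 1 `O=C1C=C(N2CCC2)C(=O)c2c1nc1n2[C@H]2OC[C@@H](O)[C@H]2OC1`: > 16000 nM
- Compound 2 `O=C1C(NC2CCCC2)=CC(=O)c2c1nc1n2[C@H]2OC[C@@H](O)[C@H]2OC1`: > 16000 nM
- Compound 3 `O=C1C(N2CCCCC2)=CC(=O)c2c1nc1n2[C@H]2OC[C@@H](O)[C@H]2OC1`: > 8000 nM

In a functional assay on ECa-109 cells for inhibition, with ECa-109 cell line (Homo sapiens) as the target, read by sulforhodamine B assay (a lower number here means a stronger inhibitor, a higher number a weaker inhibitor), compound 2 gives > 16000 nM, which is a limit and not a number. Compound 1 gives > 16000 nM, also a limit. Compound 3 gives > 8000 nM, again a limit. No number has been read so far: the limit of > 16000 nM in this assay, at which 2 of the 3 values shown sit, and (the limit of > 8000 nM in this assay, at which 1 of the 3 values shown sits).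

Compound 4 `O=C1C(Nc2ccc(C(F)(F)F)cc2)=CC(=O)c2c1nc1n2[C@H]2OC[C@@H](O)[C@H]2OC1` has not yet been measured. It differs from compound 2 as follows: 4-(trifluoromethyl)phenyl in place of cyclopentyl on an amine nitrogen.

Among the measured compounds shown here, the only measured step that bears on this change is a step that the two limits leave unreadable from compound 2 to compound 3. That step gives no size to carry over, so the expectation stays close to the limits, with only a slight lean towards stronger inhibition. The expected change is an at least 1.6-fold lower number from compound 2 to compound 4 (0.20 log units; that floor lies within the scatter). For compound 4 the estimate is 10000 nM, with an expected range from 3000 nM to 30000 nM.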

Compound 4, half-maximal inhibitory concentration: 2250 nM
The estimate for compound 4 lay 4.4-fold (0.65 log units) above the measured number, outside the stated range (below it).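

In this assay, 4-(trifluoromethyl)phenyl on the amine nitrogen moves the value off the limit, giving a readable gain in inhibition: an at least 7.1-fold lower number from compound 2 to compound 4 (0.85 log units; beyond the scatter). Among the compounds shown here, the step from compound 2 to compound 3 cannot be read, so the earlier compounds showed no change at this place: the limit of > 16000 nM in this assay, at which 2 of the 4 values shown sit. Compound 3 holds a limit of its own: the limit of > 8000 nM in this assay, at which 1 of the 4 values shown sits.

The compounds shown leave open whether the gain comes from the aromatic ring itself or from the trifluoromethyl. A plain phenyl on the same amine nitrogen would separate the two.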